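This account rests on a few compounds, and the source may have more. Where it says the series, first, only, none or still open, it means among the compounds named here.

Measured so far in a functional assay on EC9706 cells (Homo sapiens) for antiproliferative activity, read by MTT assay, with a stated time of 72 h; a lower number here means a stronger inhibitor, a higher number a weaker inhibitor:
- compound 1 `Cc1ccc(NC(=S)SCC2=CCOC2=O)cc1` gives 91000 nM
- compound 2 `O=C1CC2(CO1)CSC(=S)N2c1ccc(Cl)cc1` gives 32600 nM

Compound 1 stands at the higher of the two numbers; compound 2 gives a lower number, and the gap between them lies beyond the usual scatter. Compound 2 has a different core, so this gap says nothing about a single substituent change.

The next compound, compound 3 `O=C1OCC=C1CSC(=S)Nc1ccc(Cl)cc1`, keeps the core of compound 1 and differs only in one place: chloro in place of methyl on an aromatic carbon. For the measured compounds named here, no step between measured compounds of this kind exists, so the size of the change is open. From what is known here, a step in this assay from compound 1 to compound 3 is expected to be small, at most somewhat toward a lower number, and may not exceed the scatter. Compound 3 is therefore estimated at 60000 nM, with a likely range of 20000 nM to 150000 nM; the expected step is a 1.5-fold lower number from compound 1 to compound 3 (0.18 log units; within the scatter).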

Compound 3, half-maximal inhibitory concentration: "not active" (no number reported)
No number was reported for compound 3, so the estimate cannot be set against anything.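

In this assay, for the compounds shown here, compound 3 is reported as not active, without a number, so no step from compound 1 to compound 3 can be read. The compounds shown leave open how far chloro in place of methyl on an aromatic carbon moves activity on this core. Nothing measured here bears on this result.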